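The compounds below may be only part of what the source reports. "The series", "measured", "known", "first", "only" and "open" are said of these compounds alone.

The measured compounds:

Compound 1, `COCOc1ccc(/C=C/C(=O)c2ccc(OC)cc2O)cc1CC=C(C)C`. In an assay on isolated protein for inhibition of Aromatase (Homo sapiens) (a higher number here means a weaker inhibitor, a lower number a stronger inhibitor), compound 1 gives > 261000 nM, which is a limit of the assay rather than a number.

Compound 2, `COc1ccc(C(=O)/C=C/c2ccc(O)c(CC=C(C)C)c2)c(O)c1`. In this assay compound 2 gives > 295000 nM, again a limit of the assay and not a number.

Compound 2 therefore stands at a limit: its inhibition of the enzyme is too weak for a value to be read. Among the measured compounds shown here, the one step between the measured compounds, a step that the two limits leave unreadable from compound 1 to compound 2, runs between two limits and its size cannot be read, as the lines the limit of > 261000 nM in this assay, at which 1 of the 2 values shown sits, and the limit of > 295000 nM in this assay, at which 1 of the 2 values shown sits, show.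

Compound 3 is `COc1ccc(C(=O)/C=C/c2ccc(OC)c(CC=C(C)C)c2)c(O)c1`. It differs from compound 2 by methyl in place of hydrogen on an oxygen on an aromatic ring. Compound 1 carried a methoxymethyl on that same oxygen and still gave only a limit, so the measured step offers no readable size and no direction for this change. The expectation for compound 3 is that it, too, falls at or beyond the limit of this assay, and the step that the limit leaves unreadable from compound 2 to compound 3 is estimated to lie within the scatter. Compound 3 is estimated at 300000 nM, expected between 100000 nM and 1000000 nM.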

Compound 3, half-maximal inhibitory concentration: > 283000 nM
Compound 3: a limit, no number; the forecaster's own chance of this, stated with the estimate: 80%; the middle value does not contradict the limit.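

In this assay compound 3 gives > 283000 nM, which is a limit of the assay and not a number. Among the compounds shown here, compound 1, compound 2 and compound 3 all stand at limits, and no step among them can be read. The compounds shown leave open how strongly any of them inhibits the enzyme, and whether changing the group on that oxygen alters this at all.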